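Removing the Nitro Group: What Compound 3 Might Tolerate

The source may hold more compounds than are shown below. What is called first, only, known or untested is meant among the compounds shown, and "the series" means these compounds.

Measured compounds:
compound 1, `COc1ccc(-c2cnc(NC(=O)c3cccc([N+](=O)[O-])c3)n2C)cc1`: > 100000 nM
compound 2, `Cc1cccc(C(=O)Nc2ncc(-c3ccccc3)n2C)c1`: > 50000 nM

Both compounds were tested in a toxicity assay on THP-1 cells (Homo sapiens) for inhibition; a higher number here means that more compound is tolerated, a lower number that less compound is tolerated. Compound 1 shows no number here but only a limit, > 100000 nM; this is the limit of > 100000 nM in this assay, at which 1 of the 2 values shown sits. Compound 2 likewise reaches only a limit, > 50000 nM, which is the limit of > 50000 nM in this assay, at which 1 of the 2 values shown sits. For the measured compounds named here, neither compound therefore has a measured toxicity value, and no step between them can be sized; compound 1 simply stands at the higher of the two limits, alongside the one other value shown.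

Compound 3 is `COc1ccc(-c2cnc(NC(=O)c3ccccc3)n2C)cc1` and has not yet been measured. It differs from compound 1 by one change: hydrogen in place of nitro on an aromatic carbon. Compound 2 already carries no nitro group and also stays within its limit, so nothing in the shown values suggests that taking the nitro group away should bring the toxicity readout down into a measurable range. In this assay no step beyond the scatter is expected, so the step of a number no higher from compound 1 to compound 3 (the limit leaves the size open) is estimated to be flat. Compound 3 is expected to give about 100000 nM, within a range from 40000 nM to 300000 nM, most likely again as a limit.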

Compound 3, half-maximal cytotoxic concentration: > 100000 nM
Compound 3: no number, only a limit; the forecaster's own chance of this, stated with the estimate: 80%; the middle value sits exactly at the limit.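

In this assay compound 3 gives only a limit, > 100000 nM. For the compounds shown here, compound 1 also gives only a limit, so no step between compound 1 and compound 3 can be read. The compounds shown leave open what concentration of any of them would harm the cells, and whether swapping the nitro group for hydrogen changes that concentration at all.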